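Aryl variation on the hydrazone of the compound 1 series

A few compounds are considered here, and "the series" means these few. Any claim that something is new, unique, unknown or untested is made for them only; others in the source may bear on it.

Compound 1 `CN(C)CCn1cnnc1-c1cc(Oc2ccc(NC(=O)N/N=C/c3ccc(Cl)cc3Cl)cc2F)ccn1` is measured in a functional assay on HT-29 cells (Homo sapiens) for cytotoxicity, read by MTT assay, with a stated time of 72 h (a lower number here means a stronger inhibitor, a higher number a weaker inhibitor), where compound 1 gives 390 nM, the lowest of the three numbers in hand. Compound 2 `CN(C)CCn1cnnc1-c1cc(Oc2ccc(NC(=O)N/N=C/c3cc(Br)c(O)c(Br)c3)cc2F)ccn1` gives 2670 nM and compound 3 `CN(C)CCn1cnnc1-c1cc(Oc2ccc(NC(=O)N/N=C/c3ccc(O)cc3)cc2F)ccn1` gives 1920 nM; between these two the difference, a 1.4-fold lower number from compound 2 to compound 3 (0.14 log units; within the scatter), is within the scatter, so no order between compound 2 and compound 3 is claimed.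

Compound 4 `COc1ccc(/C=N/NC(=O)Nc2ccc(Oc3ccnc(-c4nncn4CCN(C)C)c3)c(F)c2)cc1O` is the next candidate. Against compound 1 the change is 3-hydroxy-4-methoxyphenyl in place of 2,4-dichlorophenyl on a carbon with a double bond to nitrogen. The two measured steps that bear on this are both swaps at the same carbon for a phenyl carrying a hydroxyl: a 6.8-fold higher number from compound 1 to compound 2 (0.84 log units; beyond the scatter) and a 4.9-fold higher number from compound 1 to compound 3 (0.69 log units; beyond the scatter). Both moved the number upward, beyond the scatter, by a modest amount, and the 3-hydroxy-4-methoxyphenyl entering in compound 4 is again a hydroxyl-bearing phenyl in place of the 2,4-dichlorophenyl. A step of that same kind and size is therefore expected, a 4.9-fold higher number from compound 1 to compound 4 (0.69 log units; beyond the scatter), upward in the number.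

The number for compound 4 is estimated at 1900 nM, with a range from 800 nM to 4500 nM. For the measured compounds named here, whether the methoxy group shifts the outcome away from that of compound 3 cannot be read from the three compounds measured so far.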

Compound 4, half-maximal inhibitory concentration: 960 nM
Beside the measured number, compound 4's estimate is 2.0-fold (0.30 log units) above it, and the stated range covers the measured number.
By their numbers in this assay, from the lowest: compound 1; then compounds 4, 3 and 2 (each within the scatter of the next, the first and the last beyond it).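

In (this assay), a third hydroxyl-bearing phenyl on the carbon with a double bond to nitrogen again gives a higher number than the 2,4-dichlorophenyl of compound 1 (a 2.5-fold higher number from compound 1 to compound 4 (0.39 log units; beyond the scatter)), so compound 1 now stands lowest, beyond the scatter, against all three replacements. The 3-hydroxy-4-methoxyphenyl also gives the first separation among the hydroxyl-bearing phenyls (a 2.8-fold lower number from compound 2 to compound 4 (0.44 log units; beyond the scatter)), while the remaining comparison (a 2.0-fold lower number from compound 3 to compound 4 (0.30 log units; within the scatter)) lies within the scatter, so no order is claimed for that pair and compound 3 separates from neither compound 2 nor compound 4. No measurement is available that bears on the origin of these steps.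

Every replacement shown removes both chlorines and brings in a hydroxyl, so the compounds shown cannot separate the loss of chlorine from the gain of hydroxyl. Going by these compounds, a phenyl carrying a single chlorine, a methoxy group without a hydroxyl, an amine or a carboxylic acid at this carbon would test that separation, and whether any group here can match the 2,4-dichlorophenyl remains open.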